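Hydroxy for hydrogen on a chalcone: cytotoxicity expectation

The source may hold more compounds than are shown below. What is called first, only, known or untested is meant among the compounds shown, and "the series" means these compounds.

Measured so far in an ADME assay on RAW264.7 cells (Mus musculus) for cytotoxicity, read by MTT assay, with a stated time of 24 h, tested at 2.5 ug/mL; on this read-out lower numbers stand for a stronger effect and higher numbers for a weaker effect at the one concentration tested:
compound 1 `COc1ccc(/C=C/C(=O)c2ccc(OC)c(OC)c2)cc1`: 93.1%
compound 2 `COc1ccc(CCC(=O)c2ccc(OC)c(OC)c2)cc1O`: 92.1%

Compound 1 stands highest of the two numbers, but compound 2 lies within the scatter of it, so the two values show no order between them; both point to a weak effect at the concentration tested. Among the compounds with values here, no step between the two measured compounds is known, since they differ in more than one place.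

Compound 3 `COc1ccc(/C=C/C(=O)c2ccc(OC)c(OC)c2)cc1O` is still to be measured. Its change from compound 1 is hydroxy in place of hydrogen on an aromatic carbon. With both measured numbers high and close to each other, no step beyond the scatter is expected from compound 1 to compound 3, in either direction, and compound 3 is expected to stay in the weak-effect region. The expected step is a number 3.1 percentage points lower from compound 1 to compound 3 (within the scatter). For compound 3 the estimate is 90%, with a range from 78% to 99%.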

Compound 3, a percentage reported as activity, at one concentration (the size of the read-out at that concentration, not a potency): 82.1%
Compound 3: middle estimate off by 7.9 percentage points, on the high side; the range from low to high includes it.
By their numbers in this assay, from the lowest: compounds 3, 2 and 1 (each within the scatter of the next, the first and the last beyond it).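

In this assay, hydroxy in place of hydrogen on an aromatic carbon, ortho to a methoxy group and meta to a large group, gives a number 11 percentage points lower from compound 1 to compound 3 (beyond the scatter), a modest step and the first single-place change available in the series. This place on the core of compound 1 therefore responds to the change, towards a stronger effect, although compound 3 still reads 82.1% at the one concentration tested. No measurement available here bears on the reason for this step.

On these data alone, how an amine or a carboxylic acid at this same place would read in this assay stays open, so the step cannot yet be tied to hydroxy alone. As far as these compounds go, whether hydroxy at another aromatic carbon of the shared core would give a similar step also stays open.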